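A few compounds are considered here, and "the series" means these few. Any claim that something is new, unique, unknown or untested is made for them only; others in the source may bear on it.

Measured compounds:
Compound 1, `CC(C)CN1CCc2nc(C#Cc3ccccc3)sc2C1`: 650 nM
Compound 2, `O=C(C1CCCO1)N1CCc2nc(C#Cc3ccccc3)sc2C1`: > 10000 nM

In an assay on HEK293 cells for negative allosteric modulation of metabotropic glutamate receptor 5 (Homo sapiens), read by FLIPR, with a stated time of 1 h (a higher number here means a weaker inhibitor, a lower number a stronger inhibitor), compound 1 gives 650 nM. Compound 2 in this assay gives > 10000 nM, which is a limit of the assay rather than a number. Compound 2 therefore sits at the weak end of what can be reported, with its value at the limit of > 10000 nM in this assay, at which 1 of the 2 values shown sits. The step of an at least 15-fold higher number from compound 1 to compound 2 (1.18 log units; beyond the scatter) shows that exchanging isobutyl for (oxolan-2-yl)carbonyl on the amine nitrogen in the ring costs a great deal of inhibition. Compound 3 `Cc1nc(C(=O)N2CCc3nc(C#Cc4ccccc4)sc3C2)cs1` keeps the carbonyl of compound 2 and changes only the group on it: 2-methyl-1,3-thiazol-4-yl in place of oxolan-2-yl on a carbonyl carbon. For the measured compounds named here, the only measured step that bears on this, from an amine to an amide, was large and went toward weaker inhibition; no measured step compares two amides with each other. Compound 3 is therefore expected to remain weak, with the step of a number no higher from compound 2 to compound 3 (the limit leaves the size open) expected to be small. Compound 3 is estimated in this assay at 10000 nM (range 2500 nM to 40000 nM), most likely again reported only as a limit.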

Compound 3, half-maximal inhibitory concentration: > 10000 nM
Compound 3: only a limit was reported (the forecaster's own chance of this, stated with the estimate: 70%); the middle value lies on the limit itself.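

The loss of inhibition does not belong to the oxolan-2-yl group alone: in this assay a different amide, with the aromatic 2-methyl-1,3-thiazol-4-yl group on the carbonyl, also gives an at least 15-fold higher number from compound 1 to compound 3 (1.18 log units; beyond the scatter) and so lands on the weak side as well. Both amides therefore stay far from the amine compound 1, whatever the difference between their two groups may be. The steps between limits cannot be read, so the two groups cannot be ranked against each other, and compound 3 ends at a limit of the assay: the limit of > 10000 nM in this assay, at which 2 of the 3 values shown sit.

Compound 1 is the only amine shown, so it remains open whether other amines, such as a benzyl group on the same nitrogen, hold inhibition. On these data alone, it is also open whether any group on the carbonyl, such as a small methyl or a phenyl, brings inhibition back within reach of measurement.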